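From naphthalen-2-yl to 2,3-difluorophenyl on the shared core

This account rests on a few compounds, and the source may have more. Where it says the series, first, only, none or still open, it means among the compounds named here.

In a physicochemical assay for lipophilicity, using the shake flask method, measured as octanol-water partition, at pH 7.4 (on this read-out lower numbers stand for lower lipophilicity and higher numbers for higher lipophilicity), compound 1 (`CC(=O)N[C@H]1[C@H]([C@@H](O)[C@H](O)CNC(=O)c2ccc(Cl)cc2)O[C@@](OCc2ccccc2)(C(=O)O)C[C@@H]1O`) has no number, and its entry reads "not determined" (no result reported) and nothing more. Compound 2 (`CC(=O)N[C@H]1[C@H]([C@@H](O)[C@H](O)CNC(=O)c2ccc(Cl)cc2)O[C@@](OCc2ccc3ccccc3c2)(C(=O)O)C[C@@H]1O`) gives 0.58 as the only figure available, so it stands alone with nothing to compare it against. Compound 3 (`CC(=O)N[C@H]1[C@H]([C@@H](O)[C@H](O)CNC(=O)c2ccc(Cl)cc2)O[C@@](OCc2cccc(F)c2F)(C(=O)O)C[C@@H]1O`) carries 2,3-difluorophenyl in place of naphthalen-2-yl on a saturated chain carbon bound to an oxygen on a saturated carbon and awaits measurement. Among the compounds with values here, no measured step guides the expectation. In this assay a lower reading is expected, with an estimated a number 0.68 log units lower from compound 2 to compound 3 (beyond the scatter) beyond the usual scatter. For compound 3 the estimated value is -0.1 with an expected range from -0.6 to 0.3 around it.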

Compound 3, distribution coefficient: -0.27
Compound 3: the middle estimate sits 0.17 log units above what was measured; measured number inside the range.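

In this assay, this position on the shared core now has its first readable change, and replacing naphthalen-2-yl with 2,3-difluorophenyl gives a number 0.85 log units lower from compound 2 to compound 3 (beyond the scatter) in the read-out. The reading therefore responds to the group at this place, where the entering group has one aromatic ring instead of two and carries two fluorine atoms. Nothing given here accounts for the step. The compounds shown leave open how much of the step goes with the ring count and how much with the fluorine atoms. Also open, on these data alone, is how an amine or a carboxylic acid on the ring would read here.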